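Carboxy on compound 1: what the neighbours suggest

The source may report more compounds than this note shows. Statements on the series, on what has been measured and on what is new or still open speak of the compounds shown alone.

Compound 1 (`O=C1/C(=C/c2ccccc2)COC/C1=C\c1ccccc1F`) is measured in a functional assay on NCI-H1650 cells (Homo sapiens) for cytotoxicity, read by MTT assay, with a stated time of 72 h (a higher number here means a weaker inhibitor, a lower number a stronger inhibitor), alongside compound 2 (`O=C1/C(=C/c2cccc(O)c2)COC/C1=C\c1ccccc1F`) and compound 3 (`O=C1/C(=C/c2ccccc2F)COC/C1=C\c1ccc(Cl)cc1Cl`). Compound 1 gives 9600 nM in this test, compound 2 gives 5700 nM and compound 3 gives 8600 nM under the same conditions. All three numbers lie within the scatter of one another, so compound 1 holds no distinct rank among them.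

Compound 4 (`O=C1/C(=C/c2ccccc2F)COC/C1=C\c1ccccc1C(=O)O`) differs from compound 1 by carboxy in place of hydrogen on an aromatic carbon, ortho to a large group (carboxy in place of hydrogen on an aromatic carbon). The nearest guide is a 1.7-fold lower number from compound 1 to compound 2 (0.23 log units; within the scatter) with hydroxy in place of hydrogen on an aromatic carbon. A larger swap gives a 1.1-fold lower number from compound 1 to compound 3 (0.05 log units; within the scatter) with 2,4-dichlorophenyl in place of phenyl. Among the measured compounds shown here, neither of these steps leaves the scatter, yet no measured compound here carries a carboxy group, so the guidance is thin. In this assay the expected step is a 1.0-fold higher number from compound 1 to compound 4 (0.02 log units; within the scatter) and that means no shift beyond the scatter. The estimate for compound 4 is 10000 nM with an expected range from 4000 nM to 30000 nM as a deliberately broad band.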

Compound 4, half-maximal inhibitory concentration: 15200 nM
Beside the measured number, compound 4's estimate is 1.5-fold (0.18 log units) below it; the measured number falls inside the stated range.
By their numbers in this assay, from the lowest: compounds 2, 3, 1 and 4 (each within the scatter of the next, the first and the last beyond it).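

In this assay, carboxy in place of hydrogen on an aromatic carbon, ortho to a large group, gives a 1.6-fold higher number from compound 1 to compound 4 (0.20 log units; within the scatter), so adding this group of 3 heavy atoms at this place produces no shift that can be told apart from repeat-measurement noise. Among the compounds shown here, the earlier compounds carried hydroxy or chlorine on their aromatic rings but no carboxy, so this is the first reading for this group, and it shows that the cytotoxicity read-out stays measurable with carboxy at this position of the core of compound 1. No accompanying measurement speaks to why the number stays within the scatter, and nothing here supports a cause.

A single substitution cannot show whether this position is insensitive to change in general or whether this one group happens to leave the number in place. An amine or a methyl ester at the same place would help to separate those two readings, and so would carboxy on another carbon of the same ring.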